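The source may report more compounds than this note shows. Statements on the series, on what has been measured and on what is new or still open speak of the compounds shown alone.

Compound 2 `CC1(C)Cc2c(ccc(C(=O)/C=C/c3cn(-c4ccccc4)nc3-c3ccc([N+](=O)[O-])cc3)c2OCc2ccccc2)O1`: 62300 nM
Compound 1 `COc1ccc(-c2nn(-c3ccccc3)cc2/C=C/C(=O)c2ccc(O)c3c2OC(C)(C)C3)cc1`: 20800 nM
Compound 3 `CC1(C)Cc2c(ccc(C(=O)/C=C/c3ccc(Cl)cc3)c2OCc2ccccc2)O1`: a limit of the assay only, > 100000 nM

In a functional assay on PC-3 cells (Homo sapiens) for antiproliferative activity, read by MTT assay, with a stated time of 48 h (on this read-out lower numbers stand for stronger inhibition and higher numbers for weaker inhibition), compound 2 stands at the highest of the two numbers, and compound 1 sits at the lower one, a gap beyond the usual scatter. For compound 3 the assay reports only a limit, not a number. Compound 4 `Cc1ccc(-c2nn(-c3ccccc3)cc2/C=C/C(=O)c2ccc3c(c2OCc2ccccc2)CC(C)(C)O3)cc1` has not yet been measured. It differs from compound 2 in one place: methyl in place of nitro on an aromatic carbon. For the measured compounds named here, no pair of measured compounds isolates this change, since compound 1 differs from compound 2 in more than one place, so the direction of the step is open. The expected step is small, not beyond the scatter, a 1.4-fold lower number from compound 2 to compound 4 (0.14 log units; within the scatter). Compound 4 is estimated at 45000 nM, within a range from 12000 nM to 140000 nM.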

Compound 4, half-maximal inhibitory concentration: 24200 nM
For compound 4 the middle estimate is 1.9-fold (0.27 log units) above the measured one, and the stated range covers the measured number.
By their numbers in this assay, from the lowest: compounds 1 and 4 (each within the scatter of the next); then compound 2. At a limit, above all of these: compound 3.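

Replacing nitro with methyl at this position, para to a large group, is a change the cells respond to: this assay shows a 2.6-fold lower number from compound 2 to compound 4 (0.41 log units; beyond the scatter), a modest step. For the compounds shown here, this is the first measured pair to isolate one change at this position, so the group held there does affect the number. Nothing measured here explains the step. From the compounds shown here alone, whether an amine, a carboxylic acid or a longer chain at this position would give a lower or higher number stays open, and a single step sets no trend across groups.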